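Methyl to hydrogen on the ring nitrogen: a second pair

The source may hold more compounds than are shown below. What is called first, only, known or untested is meant among the compounds shown, and "the series" means these compounds.

Four compounds share one core and differ in a side chain, a fluorinated aryl group, and the substituent on a nitrogen on an aromatic ring. Compound 1 `NCCCOc1ccc(CNc2nc3ccc(Oc4ccc(C(F)(F)F)cc4)cc3s2)cc1` carries hydrogen on that nitrogen; compound 2 `CN(Cc1ccc(OCCCN)cc1)c1nc2ccc(Oc3ccc(C(F)(F)F)cc3)cc2s1` carries methyl there. In an assay on SH-SY5Y cells for inhibition of Voltage-dependent N-type calcium channel subunit alpha-1B (Homo sapiens), read by FLIPR and calcium flux, with stated times of 600 s and 300 s, in the presence of a further agent that is not named here (on this read-out lower numbers stand for stronger inhibition and higher numbers for weaker inhibition), compound 1 gives 59000 nM, and compound 2 gives 283000 nM. The change between them, (hydrogen in place of methyl on a nitrogen on an aromatic ring), brought a 4.8-fold lower number from compound 2 to compound 1 (0.68 log units; beyond the scatter).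

Compound 3 `CN(Cc1ccc(OCCCNC(=N)N)cc1)c1nc2ccc(Oc3ccc(F)cc3)cc2s1` differs from compound 2 in more than one place; how the two cores differ is not broken down here. In this assay compound 3 gives 100000 nM. Its number sits within the scatter of compound 1 and beyond the scatter of compound 2.

Compound 4 `N=C(N)NCCCOc1ccc(CNc2nc3ccc(Oc4ccc(F)cc4)cc3s2)cc1` is the unmeasured partner of compound 3, and the change is hydrogen in place of methyl on a nitrogen on an aromatic ring. The description of the place is the same word for word in both pairs, so this is the same change, seen once so far, from compound 2 to compound 1. One example gives a thin basis, and the side chain and aryl group around it are not the same, so the step is expected to be of similar direction but uncertain in size.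

For compound 4 the expected step is a 4.0-fold lower number from compound 3 to compound 4 (0.60 log units; beyond the scatter), resting on a 4.8-fold lower number from compound 2 to compound 1 (0.68 log units; beyond the scatter). In this assay compound 4 is expected to give 25000 nM, with a plausible range from 8000 nM to 80000 nM.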

Compound 4, half-maximal inhibitory concentration: 244000 nM
Beside the measured number, compound 4's estimate is 9.8-fold (0.99 log units) below it; the measured number lies above the stated range.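

In this assay, hydrogen in place of methyl on a nitrogen on an aromatic ring gave a 2.4-fold higher number from compound 3 to compound 4 (0.39 log units; beyond the scatter), so the lower number seen on the first pair did not carry over, and the direction of the step depends on the core it is placed on: the same change on two cores in this assay, a 4.8-fold lower number (0.68 log units; beyond the scatter) from compound 2 to compound 1 and a 2.4-fold higher number (0.39 log units; beyond the scatter) from compound 3 to compound 4, 12-fold (1.07 log units) apart, beyond the scatter of two such steps. The step therefore has no single direction or size that can be carried from one core to another in this series, and an estimate for a new pair cannot rest on a single earlier pair. What the two pairs do not show is which difference goes with the change of direction, as compound 1 and compound 2 carry an amine side chain and a trifluoromethyl group, while compound 3 and compound 4 carry a guanidine side chain and a fluorine.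

The compounds shown leave open whether the side chain or the aryl substituent decides the direction, and a pair with the guanidine side chain and trifluoromethyl, or with the amine side chain and fluorine, would separate the two. Also open, as far as these compounds go, is how ethyl on that nitrogen, or a longer chain carrying the amine or guanidine, would behave on either core.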